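A few compounds are considered here, and "the series" means these few. Any claim that something is new, unique, unknown or untested is made for them only; others in the source may bear on it.

Measured so far in a functional assay on SMMC-7721 cells (Homo sapiens) for cytotoxicity, read by MTT assay, with a stated time of 4 days; a lower number here means a stronger inhibitor, a higher number a weaker inhibitor:

compound 1 `C=C1C[C@]23C[C@@]1(O)CC[C@H]2c1cc(Br)c(O)c(C)c1[C@@H]3Cn1cc(-c2ccc(Cl)cc2)nn1`: 19100 nM
compound 2 `Cc1ccc(S(=O)(=O)Oc2ccc3c(c2C)[C@H](Cn2cc(-c4ccc(C(F)(F)F)cc4)nn2)[C@@]24CC(=O)[C@@](C)(CC[C@@H]32)C4)cc1`: > 20000 nM
compound 3 `Cc1c(O)ccc2c1[C@H](Cn1cc(-c3ccc(Cl)cc3)nn1)[C@@]13CC(=O)[C@@](C)(CC[C@@H]21)C3`: > 20000 nM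

Of these three, only compound 1 gave a number in this assay, namely 19100 nM. For compound 2 the result > 20000 nM is a limit of the assay and not a number. For compound 3 the result > 20000 nM is likewise a limit of the assay and not a number. Compound 3 therefore stands at the limit of > 20000 nM in this assay, at which 2 of the 3 values shown sit, with nothing to separate it from compound 2 on the numbers shown, and with compound 1 the only measured value below that limit.

Compound 4 `Cc1c(O)ccc2c1[C@H](Cn1cc(-c3ccc(C(F)(F)F)cc3)nn1)[C@@]13CC(=O)[C@@](C)(CC[C@@H]21)C3` differs from compound 3 in one place: trifluoromethyl in place of chloro on an aromatic carbon. Among the measured compounds shown here, no pair of measured compounds that differ in this one place alone is available, so the size of the step cannot be read from the data. For the measured compounds named here, compound 2 carries the same trifluoromethyl group and also sits at the limit, but it differs from compound 3 in a further place as well, so its value shows only that this group did not lift the signal out of the limit there. The step from compound 3 to compound 4 is expected to be small, none beyond the scatter, as a step that the limit leaves unreadable from compound 3 to compound 4. Compound 4 is accordingly expected to give about 30000 nM, within a range of 15000 nM to 80000 nM, most likely reported again as a limit.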

Compound 4, half-maximal inhibitory concentration: > 20000 nM
Compound 4 ended at the assay's limit; the forecaster's own chance of this, stated with the estimate: 75%; the middle value does not contradict the limit.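

In this assay compound 4 gives > 20000 nM as a limit of the assay and not a number. Among the compounds shown here, no step from compound 3 or compound 2 to compound 4 can be read, since all three sit at the same limit: the limit of > 20000 nM in this assay, at which 3 of the 4 values shown sit. The compounds shown leave open whether trifluoromethyl in place of chloro, or hydrogen in place of (4-methylphenyl)sulfonyl, changes the result in this assay at all.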